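Notes on the step from compound 3 to compound 4

The source may hold more compounds than are shown below. What is called first, only, known or untested is meant among the compounds shown, and "the series" means these compounds.

In an ADME assay on NHDF cells (Homo sapiens) for cytotoxicity, read by MTT assay, with a stated time of 72 h (a lower number here means a stronger inhibitor, a higher number a weaker inhibitor), compound 1 `COc1ccc(/C=C2\CCC/C(=C\c3ccc(Br)cc3)C2=O)cc1OC` gives 13100 nM as its value, compound 2 `COc1ccccc1/C=C1\CCC/C(=C\c2ccc(OC)c(OC)c2)C1=O` gives 18100 nM as its value and compound 3 `COc1ccc(/C=C2\CCC/C(=C\c3ccc(OC)c(OC)c3)C2=O)cc1` gives 30900 nM as its value. Two steps fix the place of the third number (a 2.4-fold higher number from compound 1 to compound 3 (0.37 log units; beyond the scatter)) (a 1.7-fold higher number from compound 2 to compound 3 (0.23 log units; within the scatter)) and only the first of them clears the scatter. Compound 4 `COc1ccc(/C=C2\CCC/C(=C\c3cccc(O)c3)C2=O)cc1OC` carries 3-hydroxyphenyl in place of 4-methoxyphenyl on a double-bonded chain carbon bound to a double-bonded ring carbon and keeps the rest of compound 3 unchanged. Going by the values given here, the same place also varies in a third measured step (a 1.4-fold higher number from compound 1 to compound 2 (0.14 log units; within the scatter)) and these three steps are the only guide. Among the compounds with values here, none of the measured compounds carries a hydroxy group, so the guide is indirect. The largest of the three steps is modest, so no step beyond the scatter is expected, with a slight lean towards a lower number (a 1.5-fold lower number from compound 3 to compound 4 (0.17 log units; within the scatter)) as the expected outcome. For compound 4 the estimated value is 21000 nM with an expected range from 9000 nM to 48000 nM in this estimate.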

Compound 4, half-maximal inhibitory concentration: 6800 nM
Beside the measured number, compound 4's estimate is 3.1-fold (0.49 log units) above it; measured number outside the range, below it.
By their numbers in this assay, from the lowest: compounds 4, 1, 2 and 3 (each within the scatter of the next, the first and the last beyond it).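

In this assay, 3-hydroxyphenyl on a double-bonded chain carbon bound to a double-bonded ring carbon gives the largest step seen at this place, a 4.5-fold lower number from compound 3 to compound 4 (0.66 log units; beyond the scatter), and it also clears the scatter against the other methoxy-bearing compound, a 2.7-fold lower number from compound 2 to compound 4 (0.43 log units; beyond the scatter). Against 4-bromophenyl there is no such separation, a 1.9-fold lower number from compound 1 to compound 4 (0.28 log units; within the scatter), so these two groups cannot be ordered here. The change to compound 4 alters both the group and where its oxygen stands on the aromatic ring, and no measurement at hand accounts for the step.

On these data alone, whether 3-methoxyphenyl or 4-hydroxyphenyl would keep this lower number remains open, and this would separate the hydroxy group from its placement. As far as these compounds go, how an amine or a carboxylic acid on the same aromatic ring would stand is equally open.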